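Amine chain series: hydroxy added to piperidin-1-yl

This account rests on a few compounds, and the source may have more. Where it says the series, first, only, none or still open, it means among the compounds named here.

Measured in a functional assay on the whole organism with Mus musculus as the target, in the maximal electroshock model, at a dose of 50 mg/kg by the oral route; on this read-out lower numbers stand for less inhibition and higher numbers for more inhibition at the one dose given (going by the name of the read-out):
compound 1, `CN(C)CCCOc1ccccc1/C=C/c1ccccc1`: 14.2%
compound 2, `C(=C/c1ccccc1OCCCCN1CCCC1)\c1ccccc1`: 42.9%
compound 3, `C(=C/c1ccccc1OCCCCN1CCCCC1)\c1ccccc1`: 42.9%

Compound 3 sits level with compound 2 at the digits shown, and these two together give the highest numbers of the three; the step of a number 28.7 percentage points higher from compound 1 to compound 3 (beyond the scatter) is the one that separates them from compound 1. The swap of ring size, no change at the digits printed from compound 2 to compound 3 (within the scatter), made no difference beyond the scatter.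

Compound 4, `OC1CCN(CCCCOc2ccccc2/C=C/c2ccccc2)CC1`, differs from compound 3 by hydroxy in place of hydrogen on a saturated ring carbon. Among the compounds with values here, no measured step touches this kind of change: the steps of a number 28.7 percentage points higher from compound 1 to compound 2 (beyond the scatter) and a number 28.7 percentage points higher from compound 1 to compound 3 (beyond the scatter) concern the amine group itself, and the step of no change at the digits printed from compound 2 to compound 3 (within the scatter) shows the ring size to be indifferent. With nothing pointing either way, a step of no more than the scatter is expected. Compound 4 is therefore expected near 40%, between 20% and 60%, which means an expected step of a number 2.9 percentage points lower from compound 3 to compound 4 (within the scatter).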

Compound 4, a percentage reported as inhibition, in the whole organism at one dose (the size of the read-out at that dose, not a potency): 0%
The estimate for compound 4 lay 40 percentage points above the measured number; the measured number lies below the stated range.
By their numbers in this assay, from the lowest: compound 4; then compound 1; then compounds 2 and 3 (each within the scatter of the next).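

In this assay the ring amine proves far from indifferent to substitution, even though the change of ring size moved nothing: hydroxy in place of hydrogen on a saturated ring carbon, three ring bonds from the ring nitrogen, gives a number 42.9 percentage points lower from compound 3 to compound 4 (beyond the scatter) on its own. The 4-hydroxypiperidin-1-yl end group also compares poorly with the other two amines, with a number 42.9 percentage points lower from compound 2 to compound 4 (beyond the scatter) and a number 14.2 percentage points lower from compound 1 to compound 4 (beyond the scatter) in the comparison with the dimethylamino end group, so this single added oxygen takes the series below its lowest earlier member. Nothing available bears on the cause of this fall.

Open, on these data alone, is whether the loss belongs to hydroxy alone or to any group at this ring carbon, which methyl or methoxy at the same place would test. Also open, as far as these compounds go, is whether hydroxy on the pyrrolidin-1-yl ring, or a longer chain carrying 4-hydroxypiperidin-1-yl, behaves the same way.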